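Benzyl Amide Expected to Remain Inactive on HeLa Cells

A few compounds are considered here, and "the series" means these few. Any claim that something is new, unique, unknown or untested is made for them only; others in the source may bear on it.

Of the compounds shown here, three sharing one core have been tested in a functional assay on HeLa cells (Homo sapiens) for cytotoxicity, read by MTT assay, with a stated time of 24 h; a lower number here means a stronger inhibitor, a higher number a weaker inhibitor. Compound 1 `C=CC1=C(C(=O)NCc2ccc(Cl)cc2)C(c2ccc(F)cc2)OC1` carries a 4-chlorobenzyl group on its amide nitrogen. In this assay compound 1 reaches only the limit > 100000 nM, a boundary of the measurement rather than a number. Compound 2 `C=CC1=C(C(=O)NCC(C)C)C(c2ccc(F)cc2)OC1` carries an isobutyl group in that place. In this assay compound 2 also stops at the limit > 100000 nM. The step that the two limits leave unreadable from compound 1 to compound 2 is not readable: both of its ends are limits. Compound 3 `C=CC1=C(C(=O)Nc2cccc(C)c2)C(c2ccc(F)cc2)OC1` bears a 3-methylphenyl group directly on the amide nitrogen. In this assay compound 3 is reported as "not active" (no number reported), with no number given. Compound 4 `C=CC1=C(C(=O)NCc2ccccc2)C(c2ccc(F)cc2)OC1` differs from compound 3 by benzyl in place of 3-methylphenyl on an amide-type nitrogen. Within the data shown here, no measured step bears directly on this change; the one available step is unreadable, and the limit of > 100000 nM in this assay, at which 2 of the 3 values shown sit, marks where the measured compounds sit. No shift in this assay beyond the scatter is therefore expected. Compound 4 is expected to give 100000 nM, within a range from 30000 nM to 300000 nM, most likely reported again only as a limit.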

Compound 4, half-maximal inhibitory concentration: > 100000 nM
Compound 4: no number, only a limit; the forecaster's own chance of this, stated with the estimate: 90%; the middle value lies on the limit itself.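

No new step can be read for compound 4, because its comparisons with compound 1 and compound 2 have a limit at both ends rather than a number: the limit of > 100000 nM in this assay, at which 3 of the 4 values shown sit. The compounds shown leave open whether any group on the amide nitrogen gives a measurable value in this assay at all.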